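From pyridazin-3-yl to 3,5-difluoropyridin-2-yl under a solubility limit

A few compounds are considered here, and "the series" means these few. Any claim that something is new, unique, unknown or untested is made for them only; others in the source may bear on it.

Compound 1 (`FC(F)(F)c1cccc(-c2nc3cnc(Nc4cnccn4)cc3[nH]2)c1`) and compound 2 (`FC(F)(F)c1cccc(-c2nc3cnc(Nc4cccnn4)cc3[nH]2)c1`) share one core and differ in a single place, the group on a nitrogen on an aromatic ring. Both were tested in a physicochemical assay for solubility, using the shake flask method, in phosphate buffer, measured as kinetic solubility, with a stated time of 20 h, at pH 6.5; on this read-out lower numbers stand for lower solubility and higher numbers for higher solubility. Compound 1 gives < 5000 nM, which is a limit and not a number. Compound 2 gives < 5000 nM, which is also a limit, so it has no exact standing. The whole record so far is the limit of < 5000 nM in this assay, at which 2 of the 2 values shown sit.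

Compound 3 (`Fc1cnc(Nc2cc3[nH]c(-c4cccc(C(F)(F)F)c4)nc3cn2)c(F)c1`) keeps the same core and carries 3,5-difluoropyridin-2-yl in place of pyridazin-3-yl on a nitrogen on an aromatic ring.

For the measured compounds named here, only one measured step bears on this swap of one ring for another. It is a step that the two limits leave unreadable from compound 1 to compound 2, so it offers no size to carry over, and no step beyond the usual scatter is expected, in either direction. The estimated step is a step that the limit leaves unreadable from compound 2 to compound 3. Compound 3 is expected near 3000 nM, with an estimated range of 1000 nM to 7000 nM, and this assay may well report only a limit again.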

Compound 3, solubility: < 5000 nM
Compound 3 was reported as a limit; the forecaster's own chance of this, stated with the estimate: 85%; the middle value lies beyond the limit too.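

In this assay compound 3 gives < 5000 nM, which is a limit and not a number. The steps among compound 1, compound 2 and compound 3 therefore cannot be read. The compounds shown leave open how pyrazin-2-yl, pyridazin-3-yl and 3,5-difluoropyridin-2-yl compare in solubility, because the whole record is a single limit: the limit of < 5000 nM in this assay, at which 3 of the 3 values shown sit.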